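A few compounds are considered here, and "the series" means these few. Any claim that something is new, unique, unknown or untested is made for them only; others in the source may bear on it.

Among the measured compounds shown here, compound 1 `CC(O)(C(=O)Nc1ccc(S(=O)(=O)c2cccc(O)c2)cc1)C(F)(F)F` is the only member of this small set with a number in a functional assay (Cavia porcellus) with sulfonylurea receptors; K-ATP channels (Homo sapiens) as the target; a higher number here means a weaker inhibitor, a lower number a stronger inhibitor: compound 1 gives 18000 nM. Compound 2 `CC(O)(C(=O)Nc1ccc([N+](=O)[O-])c(S(=O)(=O)c2ccccc2)c1)C(F)(F)F`, which carries a phenylsulfonyl group and a nitro group on the core, reaches only (the limit of > 30000 nM in this assay, at which 1 of the 2 values shown sits), a limit and not a number, so that in this assay compound 2 is recorded as > 30000 nM without a value behind it.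

Compound 3 `CN(c1ccccc1)S(=O)(=O)c1ccc(NC(=O)C(C)(O)C(F)(F)F)cc1` has not yet been measured in this assay. It differs from compound 1 in one place: methyl(phenyl)amino in place of 3-hydroxyphenyl on a sulfonyl sulfur. For the measured compounds named here, no measured pair here shows the effect of such a change, so the direction is open. Compound 3 is expected to stay weak, with a step from compound 1 of a 1.4-fold higher number from compound 1 to compound 3 (0.14 log units; within the scatter), no larger than the scatter or slightly towards a weaker inhibitor. Compound 3 is estimated at 25000 nM, in a range from 8000 nM to 60000 nM.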

Compound 3, half-maximal inhibitory concentration: 2000 nM
Beside the measured number, compound 3's estimate is 13-fold (1.10 log units) above it; measured number below the stated range.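

In this assay, among the compounds shown here, methyl(phenyl)amino in place of 3-hydroxyphenyl on a sulfonyl sulfur gives a 9.0-fold lower number from compound 1 to compound 3 (0.95 log units; beyond the scatter), the first step in this set that can be read, and it shows that the group at this position can move the number. The hydrogen-bond donor and acceptor counted on the leaving group are absent from the entering one, so a stronger inhibitor at this position does not require the hydroxyl of 3-hydroxyphenyl. Nothing measured here accounts for the size of this step.

This single pair cannot separate the roles of the added nitrogen, its methyl and the lost hydroxyl. A plain phenyl, an ethyl in place of the methyl, or a ring amine such as piperidine on the same sulfur would each bear on that question.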